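Removing the Chloro Between Two Ring Nitrogens of Compound 1

The source may hold more compounds than are shown below. What is called first, only, known or untested is meant among the compounds shown, and "the series" means these compounds.

Compound 1 `ClCc1ccc(Cn2cnc3nc(Cl)nc(Cl)c32)cc1` holds the lower of the two numbers measured in a functional assay on UO-31 cells (Homo sapiens) for cytotoxicity, read by sulforhodamine B assay, with a stated time of 48 h; on this read-out lower numbers stand for stronger inhibition of growth and higher numbers for weaker inhibition of growth; in that assay compound 1 gives 1440 nM. Compound 2 `Nc1nc(Cl)c2ncn(Cc3cccc(CCl)c3)c2n1` gives 13500 nM in this assay, a higher number beyond the scatter. Compound 3 `ClCc1ccc(Cn2cnc3ncnc(Cl)c32)cc1` differs from compound 1 in one place: hydrogen in place of chloro on an aromatic carbon. Among the measured compounds shown here, no measured pair shows this change, so its size is open. A small loss is expected, the estimated step being a 2.4-fold higher number from compound 1 to compound 3 (0.39 log units; beyond the scatter) in this assay, at the edge of the scatter. Compound 3 is therefore expected to give 3500 nM in this assay, within 1000 nM to 12000 nM.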

Compound 3, concentration for 50% growth inhibition: 4780 nM
Estimate against measurement, compound 3: 1.4-fold (0.14 log units) below, within the range that was stated.
By their numbers in this assay, from the lowest: compound 1; then compound 3; then compound 2.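

In this assay, among the compounds shown here, replacing the chloro between two ring nitrogen atoms with hydrogen gives a 3.3-fold higher number from compound 1 to compound 3 (0.52 log units; beyond the scatter), the first direct reading of this change. The chloro at this position therefore contributes modestly to growth inhibition, yet its removal does not abolish it, as compound 3 still gives 4780 nM here. No evidence is available to explain this step. Going by these compounds, whether a fluoro, methyl or methoxy group on this carbon would match the chloro remains open. So does the effect of replacing the other chloro, which lies meta to this position.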